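Removing the Methylpiperazine from Compound 1

The compounds below may be only part of what the source reports. "The series", "measured", "known", "first", "only" and "open" are said of these compounds alone.

Measured so far in a functional assay on MDA-MB-231 cells (Homo sapiens) for cytotoxicity, read by MTT assay, with a stated time of 72 h; a lower number here means a stronger inhibitor, a higher number a weaker inhibitor:
Compound 1 `CN1CCN(c2ccc(NC(=N)c3cc4cn[nH]c4cn3)cc2)CC1` gives 47500 nM.
Compound 2 `COc1ccc(Cn2cc3cc(C(=N)Nc4cccc(C(F)(F)F)c4)ncc3n2)cc1` gives 15500 nM.
Compound 3 `CN1CCN(c2ccc(NC(=N)c3cc4cnn(C)c4cn3)cc2)CC1` gives 30200 nM.

Among these three numbers compound 1 has the highest, so it is the weakest inhibitor of the set; compound 3 sits nearest to it, and compound 2 lies furthest away. Going by the values given here, the only one-point step recorded is a 1.6-fold lower number from compound 1 to compound 3 (0.20 log units; within the scatter), which concerns a methyl on a ring nitrogen.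

Compound 4 `N=C(Nc1ccccc1)c1cc2cn[nH]c2cn1` differs from compound 1 in another way: hydrogen in place of 4-methylpiperazin-1-yl on an aromatic carbon. Among the compounds with values here, no measured pair shows what losing this group does, so there is nothing to anchor the direction, and the step of a 1.3-fold higher number from compound 1 to compound 4 (0.10 log units; within the scatter) is expected to stay within the scatter. The estimate for compound 4 in this assay is therefore 60000 nM, with a range from 20000 nM to 200000 nM.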

Compound 4, half-maximal inhibitory concentration: > 50000 nM
Compound 4 was reported as a limit (the forecaster's own chance of this, stated with the estimate: 20%); the middle value does not contradict the limit.
By their numbers in this assay, from the lowest: compounds 2, 3 and 1 (each within the scatter of the next, the first and the last beyond it). At a limit, above all of these: compound 4.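

In this assay, replacing 4-methylpiperazin-1-yl with hydrogen on the aromatic carbon gives an at least 1.0-fold higher number from compound 1 to compound 4 (0.02 log units; that floor lies within the scatter), the only pair shown for this position. On these data alone, that step is a floor within the scatter, so the number does not fall when the group leaves, while the true size of any rise stays unknown. Compound 4 carries a limit rather than a number: the limit of > 50000 nM in this assay, at which 1 of the 4 values shown sits.

The compounds shown leave open how far the number rises on removal. They also leave open whether a morpholine or a carboxylic acid at this place would lower it.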